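The source may report more compounds than this note shows. Statements on the series, on what has been measured and on what is new or still open speak of the compounds shown alone.

Working notes on the series in an ADME assay on SH-SY5Y cells (Homo sapiens) for cytotoxicity, read by MTT assay, with a stated time of 72 h; a higher number here means a weaker inhibitor, a lower number a stronger inhibitor. Compound 1 (`O=C(CN1CCN(C(=O)c2ccccc2)CC1)N1CCN(CCCc2c[nH]c3ccccc23)CC1`) reads > 200000 nM, which is a limit of the assay and not a number. Among the measured compounds shown here, compound 2 (`COc1ccc(C(=O)N2CCN(CC(=O)N3CCN(CCCc4c[nH]c5ccccc45)CC3)CC2)cc1`) gives 148000 nM, the only true number so far in this assay. The next step leads to compound 3 (`O=C(CN1CCN(C(=O)c2ccc(Br)cc2)CC1)N1CCN(CCCc2c[nH]c3ccccc23)CC1`), with bromo in place of methoxy on an aromatic carbon, para to a large group: bromo in place of methoxy on an aromatic carbon. For the measured compounds named here, the one measured step that bears on this carbon is an at least 1.3-fold lower number from compound 1 to compound 2 (0.13 log units; that floor lies within the scatter), with methoxy in place of hydrogen. Going by the values given here, that step offers no size beyond the scatter to carry over, and no measured step has bromo on this carbon. The estimated change is therefore a 1.1-fold lower number from compound 2 to compound 3 (0.06 log units; within the scatter), and no shift beyond the scatter is expected. For compound 3 the expected value is 130000 nM, with an estimated range of 65000 nM to 200000 nM.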

Compound 3, half-maximal inhibitory concentration: 59300 nM
Compound 3: middle estimate off by 2.2-fold (0.34 log units), on the high side; measured number outside the range, below it.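

Among the compounds shown here, at this position, para to a large group, the choice of substituent does move the reading in this assay: bromo in place of methoxy gives a 2.5-fold lower number from compound 2 to compound 3 (0.40 log units; beyond the scatter), and this is the first step with true numbers at both ends. Bromo in place of hydrogen gives an at least 3.3-fold lower number from compound 1 to compound 3 (0.52 log units; beyond the scatter), so this step clears the scatter, which the floor of the methoxy step did not. Compound 1 stands at a limit of the assay and not at a number, so this step is a floor only: the limit of > 200000 nM in this assay, at which 1 of the 3 values shown sits.

Going by these compounds, it remains open whether the lower number is particular to bromo or also appears with chloro, an amine or a carboxylic acid on this carbon. Also open, on these data alone, is whether bromo elsewhere on the same ring gives a step of similar size.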